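From pyridin-2-yl to 1H-pyrazol-1-yl in compound 4

The source may hold more compounds than are shown below. What is called first, only, known or untested is meant among the compounds shown, and "the series" means these compounds.

- Compound 1 `O=C(NC1CC1)C1CCN(c2cnccc2-c2ccccn2)CC1`: 1.3
- Compound 2 `O=C(NC1CC1)C1CCN(c2cncnc2-c2ccccc2)CC1`: 1.8
- Compound 3 `CN(C)C(=O)C1CCN(c2cnccc2-c2ccccn2)CC1`: 1.2

These three values come from a physicochemical assay for lipophilicity, at pH 7.4; on this read-out lower numbers stand for lower lipophilicity and higher numbers for higher lipophilicity. Compound 3 gives 1.2, level with compound 1 within the usual scatter, while compound 2 stands clearly higher than both.

The next compound to be measured is compound 4 `CN(C)C(=O)C1CCN(c2cnccc2-n2cccn2)CC1`. It differs from compound 3 in one place: 1H-pyrazol-1-yl in place of pyridin-2-yl on an aromatic carbon. A five-membered aromatic ring with 2 hetero atoms thus replaces a six-membered aromatic ring with 1 hetero atom.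

Among the compounds with values here, only one measured step involves a single change, dimethylamino in place of cyclopropylamino on a carbonyl carbon: a number 0.10 log units lower from compound 1 to compound 3 (within the scatter). That change lies elsewhere in the molecule, so it gives no direct size for this exchange. Compound 2 differs from compound 3 in more than one place, so it gives no size either. Within the data shown here, no measured pair tests this exchange, so the expectation is loose, and no step beyond the scatter is expected in this assay. The expected step is no change at the digits printed from compound 3 to compound 4 (within the scatter). For compound 4 the estimated value is 1.2, with an expected range from 0.8 to 1.6.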

Compound 4, distribution coefficient: 1.1
For compound 4 the middle estimate is 0.10 log units above the measured one; measured number inside the range.
By their numbers in this assay, from the lowest: compounds 4, 3 and 1 (each within the scatter of the next); then compound 2.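

In this assay, within the data shown here, placing 1H-pyrazol-1-yl where pyridin-2-yl stood gives a number 0.10 log units lower from compound 3 to compound 4 (within the scatter), and this is the first measured pair to test this exchange at this position, on an aromatic carbon ortho to a large group and opposite the ring nitrogen. The step shows that, on this core with the dimethylamino amide, a five-membered aromatic ring with 2 hetero atoms can replace a six-membered aromatic ring with 1 hetero atom without a change beyond the scatter, even though the entering group has 5 heavy atoms rather than 6 and 2 hydrogen-bond acceptors rather than 1. Nothing measured here explains why the two groups read alike in this assay.

From the compounds shown here alone, this is a single pair, so it remains open whether the same exchange would behave alike with the cyclopropylamino amide of compound 1 or at another place on the core. Going by these compounds, it is also open how far the read-out would move with quite different groups at this position, such as a carboxylic acid, an amine or a longer chain.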